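Ortho halogen replaces para methyl on the aryl group

The compounds below may be only part of what the source reports. "The series", "measured", "known", "first", "only" and "open" are said of these compounds alone.

Measured compounds:
compound 1 `N#CC1=C(N)OC(c2c[nH]c3ccccc23)=C(C#N)C1c1ccc(Br)cc1` with 22.7%
compound 2 `Cc1ccccc1C1C(C#N)=C(N)OC(c2c[nH]c3ccccc23)=C1C#N` with 25.7%
compound 3 `Cc1ccc(C2C(C#N)=C(N)OC(c3c[nH]c4ccccc34)=C2C#N)cc1` with 8.5%

In a functional assay, tested at 400 ug/mL (on this read-out higher numbers stand for a stronger effect at the one concentration tested and lower numbers for a weaker effect), compound 3 gives the lowest of the three numbers, with a number 14.2 percentage points lower from compound 1 to compound 3 (beyond the scatter) and a number 17.2 percentage points lower from compound 2 to compound 3 (beyond the scatter) both beyond the scatter. Compound 4 `N#CC1=C(N)OC(c2c[nH]c3ccccc23)=C(C#N)C1c1ccccc1Cl` differs from compound 3 by 2-chlorophenyl in place of 4-methylphenyl on a saturated ring carbon. Within the data shown here, two measured steps bear on this: a number 17.2 percentage points lower from compound 2 to compound 3 (beyond the scatter) shows that moving the methyl from the 2-position to the 4-position lowered the read-out, and a number 14.2 percentage points lower from compound 1 to compound 3 (beyond the scatter) shows that a methyl in place of bromo lowered it as well. Compound 4 reverses both features, so a modest rise is expected. The expected step is a number 16.5 percentage points higher from compound 3 to compound 4 (beyond the scatter). For compound 4 the estimate in this assay is 25%, with a range from 12% to 40%.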

Compound 4, a percentage reported as activity, at one concentration (the size of the read-out at that concentration, not a potency): 21.4%
For compound 4 the middle estimate is 3.6 percentage points above the measured one; measured number inside the range.
By their numbers in this assay, from the lowest: compound 3; then compounds 4, 1 and 2 (each within the scatter of the next).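

In this assay, 2-chlorophenyl in place of 4-methylphenyl gives a number 12.9 percentage points higher from compound 3 to compound 4 (beyond the scatter), which leaves compound 3 alone at the bottom of the four. Chloro in place of methyl gives a number 4.3 percentage points lower from compound 2 to compound 4 (within the scatter) and 2-chlorophenyl in place of 4-bromophenyl gives a number 1.3 percentage points lower from compound 1 to compound 4 (within the scatter), so on this saturated ring carbon only 4-methylphenyl stands apart from the other aryl groups shown. Nothing at hand explains this difference. The compounds shown leave open how 4-chlorophenyl would compare with 2-chlorophenyl. They also leave open how an aryl group carrying an amine or a carboxylic acid would read here.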